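This account rests on a few compounds, and the source may have more. Where it says the series, first, only, none or still open, it means among the compounds named here.

Measured compounds:
compound 1 `COc1ccc(Cn2cc[nH]c2=S)cc1OC` — 339000 nM
compound 2 `S=c1[nH]ccn1Cc1cc(Cl)cc(Cl)c1` — 2400 nM

In an assay on isolated protein for inhibition of Dopamine beta-hydroxylase (Rattus norvegicus) (a higher number here means a weaker inhibitor, a lower number a stronger inhibitor), compound 1 gives 339000 nM, the higher of the two numbers. Compound 2 gives 2400 nM, a gap to compound 1 that lies beyond the scatter. Compound 3 `COc1ccc(Cn2cc[nH]c2=S)cc1C` has not been measured. It differs from compound 1 by methyl in place of methoxy on an aromatic carbon. Going by the values given here, no measured pair shows this change, so the expected step is uncertain; a modest move toward a lower number is expected, a 2.3-fold lower number from compound 1 to compound 3 (0.35 log units; beyond the scatter). Compound 3 is thus estimated at 150000 nM, with a range from 40000 nM to 500000 nM.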

Compound 3, half-maximal inhibitory concentration: 69200 nM
Compound 3: the middle estimate sits 2.2-fold (0.34 log units) above what was measured; measured number inside the range.
By their numbers in this assay, from the lowest: compound 2; then compound 3; then compound 1.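

In this assay, methyl in place of methoxy on the aromatic carbon ortho to a methoxy group and meta to a group of 7 heavy atoms gives a 4.9-fold lower number from compound 1 to compound 3 (0.69 log units; beyond the scatter). Going by these compounds alone, this is the first single change that can be read, and it shows that the oxygen of this methoxy is not required for inhibition at this position. Nothing measured here explains the step. The compounds shown leave open how a hydroxyl, an amine or a longer chain at this position would compare, and whether the remaining methoxy matters.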